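This account rests on a few compounds, and the source may have more. Where it says the series, first, only, none or still open, it means among the compounds named here.

Values measured in a functional assay on MGC-803 cells (Homo sapiens) for antiproliferative activity, read by MTT assay, with a stated time of 48 h; on this read-out lower numbers stand for stronger inhibition and higher numbers for weaker inhibition:
compound 1 `COc1ccc(CN(C(=O)Cn2cc(COc3cc(=O)oc4ccccc34)nn2)c2cc(OC)c(OC)c(OC)c2)cc1` gives 3660 nM
compound 2 `COc1ccc(CN(C(=O)Cn2cc(COc3ccc4ccc(=O)oc4c3)nn2)c2cc(OC)c(OC)c(OC)c2)cc1` gives 180 nM
compound 3 `COc1ccc(CN(C(=O)Cn2cc(CSc3nc4ccccc4o3)nn2)c2cc(OC)c(OC)c(OC)c2)cc1` gives 1850 nM

Compound 3 stands second highest of the three numbers in this assay. Its nearest neighbour is compound 1, with a 2.0-fold lower number from compound 1 to compound 3 (0.30 log units; within the scatter), a gap that means nothing. Its furthest is compound 2, with a 10-fold higher number from compound 2 to compound 3 (1.01 log units; beyond the scatter), a large step.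

Compound 4 `COc1ccc(CN(C(=O)Cn2cc(CNS(=O)(=O)c3ccc(Br)cc3)nn2)c2cc(OC)c(OC)c(OC)c2)cc1` differs from compound 3 in one place: ((4-bromophenyl)sulfonyl)amino in place of (1,3-benzoxazol-2-yl)sulfanyl on a saturated chain carbon bound to an aromatic carbon. Among the measured compounds shown here, two measured steps alter this same place, the one from compound 1 to compound 3 and the one from compound 2 to compound 3, and they show that changing the group here can leave the number almost untouched or move it by a large amount. Neither of them introduces a sulfonylamino group or a bromine, so they give no direction for compound 4. Without a guiding precedent, the expectation for compound 4 is a step of a 1.4-fold higher number from compound 3 to compound 4 (0.13 log units; within the scatter) in this assay, not beyond the scatter, with wide uncertainty either way. Compound 4 is therefore estimated at 2500 nM, within a range from 600 nM to 10000 nM.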

Compound 4, half-maximal inhibitory concentration: 430 nM
The estimate for compound 4 lay 5.8-fold (0.76 log units) above the measured number, outside the stated range (below it).
By their numbers in this assay, from the lowest: compound 2; then compound 4; then compounds 3 and 1 (each within the scatter of the next).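

Notes on the position on a saturated chain carbon bound to an aromatic carbon, in this assay: this position accepts ((4-bromophenyl)sulfonyl)amino, with one six-membered aromatic ring of carbon only and 1 hydrogen-bond donor, and the number improves on the fused-ring groups of two earlier compounds, with a 4.3-fold lower number from compound 3 to compound 4 (0.63 log units; beyond the scatter) and an 8.5-fold lower number from compound 1 to compound 4 (0.93 log units; beyond the scatter). A second aromatic ring in the group is therefore not needed for a number in this range. The coumarin-like group of compound 2 still gives the lowest number, with a 2.4-fold higher number from compound 2 to compound 4 (0.38 log units; beyond the scatter).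

The compounds shown do not separate the contribution of the bromine from that of the sulfonylamino link, and they leave open how a ring carrying chlorine, methoxy or a carboxylic acid in place of bromine would read. No measurement here bears on the cause of these steps.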